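The compounds below may be only part of what the source reports. "The series", "measured", "known", "first", "only" and "open" are said of these compounds alone.

Compound 1 `COc1ccc2nc(C)cc(NCc3ccc(C(F)(F)F)cc3)c2c1` gives 7600 nM
Compound 2 `COc1cccc(CNc2cc(C)nc3ccc(OC)cc23)c1` gives 12500 nM
Compound 3 `COc1ccc2nc(C)cc(NCc3ccc(OC(F)F)cc3)c2c1` gives 14700 nM

These values come from a functional assay on MCF-10A cells (Homo sapiens) for antiproliferative activity, with a stated time of 48 h (a lower number here means that less compound is needed, a higher number that more compound is needed for the effect), and all three lie within the scatter of one another, so compound 2 at 12500 nM holds no place clearly apart from compound 1 or compound 3. Compound 4 `COc1ccc2nc(C)cc(NCc3cccc(CO)c3)c2c1` has not yet been measured. It differs from compound 2 by hydroxymethyl in place of methoxy on an aromatic carbon in a single change, hydroxymethyl in place of methoxy on an aromatic carbon, meta to a large group. For the measured compounds named here, no measured step covers this exchange. Going by the values given here, the only step between measured compounds that differ in one place is a 1.9-fold higher number from compound 1 to compound 3 (0.29 log units; within the scatter) for difluoromethoxy in place of trifluoromethyl on an aromatic carbon, and it involves neither of the groups at issue. No step beyond the scatter is therefore expected in this assay in either direction. The expected step is a 1.1-fold higher number from compound 2 to compound 4 (0.05 log units; within the scatter) on this reading. For compound 4 the estimated value is 14000 nM with an expected range from 6500 nM to 30000 nM for repeated measurements.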

Compound 4, half-maximal effective concentration: 24700 nM
For compound 4 the middle estimate is 1.8-fold (0.25 log units) below the measured one; the range from low to high includes it.
By their numbers in this assay, from the lowest: compounds 1, 2, 3 and 4 (each within the scatter of the next, the first and the last beyond it).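

Hydroxymethyl in place of methoxy on an aromatic carbon, meta to a large group, gives a 2.0-fold higher number from compound 2 to compound 4 (0.30 log units; within the scatter) in this assay. For the compounds shown here, this is the first step at this position, and it shows that the exchange, which keeps the count of heavy atoms but brings 1 hydrogen-bond donor where methoxy has 0, does not separate the two numbers beyond the scatter; the one earlier step concerned only trifluoromethyl and difluoromethoxy. Nothing at hand beyond these numbers bears on this result.

As far as these compounds go, whether an aminomethyl group or a carboxylic acid at the same place would give a step beyond the scatter stays open. So does whether hydroxymethyl would behave alike on the carbon that carries trifluoromethyl in compound 1.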